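Methoxy for hydroxyl on the pendant aryl ring

The source may report more compounds than this note shows. Statements on the series, on what has been measured and on what is new or still open speak of the compounds shown alone.

Of the compounds shown here, two carry a number so far. Compound 1 `COc1ccc(-c2cc3ccccc3c(-c3cccc(O)c3)n2)cc1` gives 5360 nM in a functional assay on DU-145 cells (Homo sapiens) for cytotoxicity, read by CCK-8 assay and cell counting, with a stated time of 72 h; on this read-out higher numbers stand for weaker inhibition and lower numbers for stronger inhibition. Compound 2 `COc1ccc(-c2cc3cc(C)ccc3c(-c3cccc(O)c3)n2)cc1OC`, which adds a methyl on the fused ring and a second methoxy on the other pendant aryl, gives 6510 nM in this assay; this is the higher of the two numbers, yet the gap to compound 1 lies within the scatter, so no order between them can be claimed.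

Compound 3 `COc1ccc(-c2nc(-c3ccc(OC)c(OC)c3)cc3cc(C)ccc23)cc1` has not been measured. It differs from compound 2 in one place: 4-methoxyphenyl in place of 3-hydroxyphenyl on an aromatic carbon, on an aromatic carbon next to the ring nitrogen. Among the measured compounds shown here, no measured pair isolates this change, so there is no step to lean on. With both measured numbers sitting close together, the step from compound 2 to compound 3 in this assay is expected to be small, a 1.2-fold higher number from compound 2 to compound 3 (0.09 log units; within the scatter), and not confidently beyond the scatter in either direction. Compound 3 is estimated at 8000 nM, with a range from 3000 nM to 22000 nM.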

Compound 3, half-maximal inhibitory concentration: > 50000 nM
Compound 3: only a limit was reported; the forecaster's own chance of this, stated with the estimate: 15%; middle value at least 6.2-fold (0.79 log units) away from the limit.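

Among the compounds shown here, the aromatic carbon next to the ring nitrogen is the first place where a single change moves the read-out beyond the scatter: in this assay, 4-methoxyphenyl in place of 3-hydroxyphenyl gives an at least 7.6-fold higher number from compound 2 to compound 3 (0.88 log units; beyond the scatter). Compound 1 and compound 2 both carry 3-hydroxyphenyl here, so neither could show how much the number depends on this group. Compound 3 has only a limit and no number, so the step gives a minimum size and not an exact one: the limit of > 50000 nM in this assay, at which 1 of the 3 values shown sits.

The change moves the oxygen on the ring and also replaces hydroxyl with methoxy, and the compounds shown do not separate these two differences. Going by these compounds, whether an aminophenyl or a phenyl bearing a carboxylic acid at this carbon would stay close to compound 2 remains open.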